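This account rests on a few compounds, and the source may have more. Where it says the series, first, only, none or still open, it means among the compounds named here.

Measured so far in an ADME assay on a cell-free system (plasma, Homo sapiens) for metabolic stability, with Plasma (Rattus norvegicus) as the target, read by HPLC, at pH 7.4; a lower number here means that the compound disappears faster, a higher number that the compound lasts longer:
compound 1 `COc1ccccc1C(=O)O[C@@H]1CO[C@H]2[C@@H]1OC[C@@H]2OC(=O)c1ccccc1OC(C)=O`: 0.0578 h
compound 2 `COc1ccc(C(=O)O[C@@H]2CO[C@H]3[C@@H]2OC[C@@H]3OC(=O)c2ccccc2OC(C)=O)cc1`: 0.0525 h
compound 3 `CC(=O)Oc1ccccc1C(=O)O[C@H]1CO[C@H]2[C@@H]1OC[C@H]2OC(=O)c1ccc(C#N)cc1`: 0.0888 h

All three share one core and differ only in the aromatic acid that forms one of the two esters. Compound 3 has the highest of the three numbers, but the margin is slight: the step of a 1.5-fold higher number from compound 1 to compound 3 (0.19 log units; within the scatter) and the step of a 1.7-fold higher number from compound 2 to compound 3 (0.23 log units; within the scatter) both stay inside the scatter of repeated measurements, as does the step of a 1.1-fold lower number from compound 1 to compound 2 (0.04 log units; within the scatter). Within this set the three numbers are therefore best read as one short half-life rather than as a ranking.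

Compound 4 `CC(=O)Oc1ccccc1C(=O)O[C@H]1CO[C@H]2[C@@H]1OC[C@H]2OC(=O)CO[N+](=O)[O-]` alters the same position in a different way: (nitrooxy)methyl in place of 4-cyanophenyl on a carbonyl carbon. For the measured compounds named here, none of the measured steps bears directly on this change. Each of them swaps one substituted benzene ring for another, whereas here the aromatic ring leaves altogether and a short chain takes its place, so the three steps offer no guide to direction. The only anchor is that all three measured compounds fall within the scatter of one another despite carrying different aromatic acids. The expected step of a 1.5-fold lower number from compound 3 to compound 4 (0.17 log units; within the scatter) is therefore small, with a wide band of uncertainty. Compound 4 is estimated at 0.06 h, with a range from 0.02 h to 0.18 h.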

Compound 4, half-life: 0.06 h
Beside the measured number, compound 4's estimate shows no gap at the digits printed; measured number inside the range.
By their numbers in this assay, from the lowest: compounds 2, 1, 4 and 3 (each within the scatter of the next).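

In this assay, the group on this carbonyl carbon need not be an aromatic ring for the half-life to stay in the same range: with (nitrooxy)methyl in that place, a 1.5-fold lower number from compound 3 to compound 4 (0.17 log units; within the scatter), a 1.1-fold higher number from compound 2 to compound 4 (0.06 log units; within the scatter) and a 1.0-fold higher number from compound 1 to compound 4 (0.02 log units; within the scatter). The earlier compounds shown here only exchanged one substituted benzene ring for another, whereas here the ring is gone altogether and an open chain stands in its place, yet compound 4 cannot be told apart from any of the three aromatic esters. Nothing available explains what sets the half-life across these four compounds. 

The compounds shown leave open whether a longer chain ending in the same nitrooxy group, or a chain ending in an amine or a carboxylic acid, would also stay within the scatter of these four. They also cannot separate the contribution of the short chain from that of its nitrooxy end, so a plain ethyl group in the same place remains an open comparison.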